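The compounds below may be only part of what the source reports. "The series", "measured", "known", "first", "only" and "open" are said of these compounds alone.

Measured compounds:
compound 1 `CCCCOC(=O)NS(=O)(=O)c1sc(CC(C)C)cc1-c1ccc(CN2CCCC2=O)cc1` gives 3.5 nM in an assay on membranes from uterus for displacement of a labelled ligand from Angiotensin type II receptor (Sus scrofa), with a stated time of 1.5 h; a higher number here means a weaker inhibitor, a lower number a stronger inhibitor
compound 2 `CCCCOC(=O)NS(=O)(=O)c1sc(CC(C)C)cc1-c1ccc(CN2C(=O)CCC2=O)cc1` gives > 10000 nM in this assay

Compound 2 stands at the limit of this assay, a value that is only a limit and not a number, as shown by the limit of > 10000 nM in this assay, at which 1 of the 2 values shown sits. One measured step exists, an at least 2800-fold higher number from compound 1 to compound 2 (3.45 log units; beyond the scatter), and it shows that the group carried on the saturated chain carbon bound to an aromatic carbon sets potency very strongly. Compound 3 `CCCCOC(=O)NS(=O)(=O)c1sc(CC(C)C)cc1-c1ccc(C(=O)c2ccnn2C)cc1` has not yet been measured. It differs from compound 2 by (1-methyl-1H-pyrazol-5-yl)carbonyl in place of (2,5-dioxopyrrolidin-1-yl)methyl on an aromatic carbon, at the position described as para to a large group. The measured step bears on this change only loosely: it tells that changes in this part of the structure can move the number very far, but it does not show which new groups restore potency. Because compound 2 sits at the limit of > 10000 nM in this assay, at which 1 of the 2 values shown sits, the step can only lead to a lower number or stay at the limit. A lower number is expected, and the expected step is an at least 160-fold lower number from compound 2 to compound 3 (2.22 log units; beyond the scatter). Compound 3 is estimated at 60 nM, within a wide range from 3 nM to 3000 nM.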

Compound 3, inhibition constant: 3.4 nM
Compound 3: the middle estimate sits 18-fold (1.25 log units) above what was measured; measured number inside the range.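

The position para to a large group does not depend on the (2-oxopyrrolidin-1-yl)methyl group of the earlier potent compound: replacing that group with (1-methyl-1H-pyrazol-5-yl)carbonyl in this assay gives a 1.0-fold lower number from compound 1 to compound 3 (0.01 log units; within the scatter), so a quite different group, with an aromatic ring and a carbonyl, does equally well here. Set against the inactive (2,5-dioxopyrrolidin-1-yl)methyl group, the same new group gives an at least 2900-fold lower number from compound 2 to compound 3 (3.46 log units; beyond the scatter), which shows that the collapse seen earlier belongs to that particular group and not to every change at this position, even though the two groups have the same count of heavy atoms. Compound 2 stands at a limit of the assay, not a number, so this step has no exact size: the limit of > 10000 nM in this assay, at which 1 of the 3 values shown sits.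

The compounds shown change the aromatic ring and the carbonyl link in one move, and they leave open which of the two matters, a question that (1-methyl-1H-pyrazol-5-yl)methyl would address. Also open, as far as these compounds go, is how a plain phenyl ring, a pyrazole without its methyl group, or a carboxylic acid at this position would behave in this assay.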